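The compounds below may be only part of what the source reports. "The series", "measured", "known", "first", "only" and "open" are said of these compounds alone.

Measured so far:
- compound 1, `CC[C@H](C)[C@H](N)CN(C(=O)[C@@H]1C[C@H]1c1ccccc1)c1ccc(-c2ccccc2)cc1`, in a functional assay for agonist activity at G protein-coupled receptor 88 (Homo sapiens), read by HTRF and cAMP accumulation (on this read-out lower numbers stand for an effect already at smaller amounts and higher numbers for an effect only at larger amounts of compound), compound 1 gives 230 nM; 800 nM (2 entries)
- compound 2, `CC[C@H](C)[C@H](N)CN(C(=O)[C@@H]1C[C@H]1c1ccccc1)c1ccc(-c2ccc(CO)cc2)cc1`, in this assay compound 2 gives 1100 nM
- compound 3, `CC[C@H](C)[C@H](N)CN(C(=O)[C@@H]1C[C@H]1c1ccccc1)c1ccc(-c2ccc(CCC(=O)OC)cc2)cc1`, in this assay compound 3 gives 110 nM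

All three share the same core and differ only in the group carried at the far end of the biphenyl portion. Compound 3 stands lowest of the two single numbers: compound 2 lies well above it, and compound 1 has two entries that do not settle on one number, as the several entries of compound 1 in this assay, 230 nM; 800 nM (2 entries) shows.

Compound 4, `CC[C@H](C)[C@H](N)CN(C(=O)[C@@H]1C[C@H]1c1ccccc1)c1ccc(-c2ccc(NS(C)(=O)=O)cc2)cc1`, is the next step from compound 3. The change is methanesulfonamido in place of 2-(methoxycarbonyl)ethyl on an aromatic carbon. Among the compounds with values here, only one measured step bears on it, a 10-fold lower number from compound 2 to compound 3 (1.00 log units; beyond the scatter), where a hydroxy-bearing group gave way to an ester chain and the number fell clearly. Within the data shown here, compound 4 moves back toward a group that, like the one in compound 2, carries a hydrogen-bond donor, so the expectation is a rise in this assay for compound 4 of roughly a 4.5-fold higher number from compound 3 to compound 4 (0.66 log units; beyond the scatter). Compound 4 is therefore estimated at 500 nM, with a likely range from 150 nM to 2000 nM.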

Compound 4, half-maximal effective concentration: 1200 nM
Beside the measured number, compound 4's estimate is 2.4-fold (0.38 log units) below it; the measured number falls inside the stated range.
By their numbers in this assay, from the lowest: compound 3; then compounds 2 and 4 (each within the scatter of the next).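

In this assay, this aromatic carbon proves sensitive to which group it carries: methanesulfonamido in place of 2-(methoxycarbonyl)ethyl gives an 11-fold higher number from compound 3 to compound 4 (1.04 log units; beyond the scatter) and cancels the advantage compound 3 held. Methanesulfonamido in place of hydroxymethyl gives a 1.1-fold higher number from compound 2 to compound 4 (0.04 log units; within the scatter) and so does not separate these two quite different groups. Both carry a hydrogen-bond donor and 2-(methoxycarbonyl)ethyl has none, which fits the numbers of these three compounds, though compound 1, with neither group, is not covered by this comparison.

Whether the donor or some other feature of these groups sets the number stays open, as nothing measured here gives a reason for the step. Going by these compounds, how an amine, a carboxylic acid or a longer ester chain on this carbon would read in this assay also remains unknown.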